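A few compounds are considered here, and "the series" means these few. Any claim that something is new, unique, unknown or untested is made for them only; others in the source may bear on it.

Measured in a physicochemical assay for solubility, in phosphate buffer, with a stated time of 18 h, at pH 7; on this read-out lower numbers stand for lower solubility and higher numbers for higher solubility:
- Compound 1 `CC(C)CN1C(=O)c2ccccc2[C@H](C(=O)Nc2ccc(F)c(C#N)c2)[C@H]1c1ccsc1`: < 1000 nM (a limit of the assay, not a number)
- Compound 2 `CC(C)CN1C(=O)c2ccccc2[C@H](C(=O)Nc2ccc(F)c(C#N)c2)[C@H]1c1ccc(C(N)=O)s1`: 19000 nM
- Compound 3 `CC(C)CN1C(=O)c2ccccc2[C@H](C(=O)Nc2ccc(F)c(C#N)c2)[C@H]1c1ccnnc1`: 28000 nM

In this assay, compound 3 stands level with compound 2, within the scatter, at a 1.5-fold higher number from compound 2 to compound 3 (0.17 log units; within the scatter). Both sit well clear of the limit of compound 1.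

Compound 4 `CC(C)CN1C(=O)c2ccccc2[C@H](C(=O)Nc2ccc(F)c(C#N)c2)[C@H]1c1cncnc1` carries pyrimidin-5-yl in place of pyridazin-4-yl on a saturated ring carbon. The two compounds have the same atoms, joined differently.

Going by the values given here, three measured steps bear on this change. Two are large, an at least 28-fold higher number from compound 1 to compound 3 (1.44 log units; beyond the scatter) and an at least 19-fold higher number from compound 1 to compound 2 (1.27 log units; beyond the scatter), and both start from a limit and replace thiophen-3-yl. The third is closer in kind, since a 1.5-fold higher number from compound 2 to compound 3 (0.17 log units; within the scatter) exchanges one group for another at the same saturated ring carbon and stays within the scatter. None of these steps compares the two groups in question, so the expectation rests on compound 3 at 28000 nM and on the close match in what is counted for the two groups.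

No step beyond the scatter is therefore expected, and the expected step is a 1.4-fold lower number from compound 3 to compound 4 (0.15 log units; within the scatter). For compound 4 the estimated value is 20000 nM, with an expected range from 7000 nM to 60000 nM.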

Compound 4, solubility: 54000 nM
Compound 4: the middle estimate sits 2.7-fold (0.43 log units) below what was measured; the range from low to high includes it.
By their numbers in this assay, from the lowest: compounds 2, 3 and 4 (each within the scatter of the next, the first and the last beyond it). At a limit, below all of these: compound 1.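

In this assay, exchanging pyridazin-4-yl for pyrimidin-5-yl, two groups with the same counted atoms, gives a 1.9-fold higher number from compound 3 to compound 4 (0.29 log units; within the scatter), so at this saturated ring carbon the rearrangement of the two ring nitrogens is not shown to matter. The new compound does, however, separate a group from 5-carbamoylthiophen-2-yl, with a 2.8-fold higher number from compound 2 to compound 4 (0.45 log units; beyond the scatter), whereas the earlier pair gave only a 1.5-fold higher number from compound 2 to compound 3 (0.17 log units; within the scatter). Compound 1 remains at a limit of the assay, and the step from thiophen-3-yl, an at least 54-fold higher number from compound 1 to compound 4 (1.73 log units; beyond the scatter), is therefore a bound and not a size: the limit of < 1000 nM in this assay, at which 1 of the 4 values shown sits.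

The compounds shown leave open whether a pyridine ring, a plain phenyl ring, or a ring carrying an amine or a carboxylic acid at this saturated ring carbon would fall in the same range as compound 2, compound 3 and compound 4. They also leave open whether pyrimidin-5-yl would keep its standing if a longer chain took the place of the isobutyl group on the ring nitrogen.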